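Swapping the aryl substituent and a predicted cytotoxicity read-out

The source may report more compounds than this note shows. Statements on the series, on what has been measured and on what is new or still open speak of the compounds shown alone.

Compound 1 `CC(C)(C)OC(=O)c1cccc(NC(=O)C2CCCN(C(=O)c3cc(C(F)(F)F)cc(C(F)(F)F)c3)C2)c1` and compound 2 `CSc1cccc(NC(=O)C2CCCN(C(=O)c3cc(C(F)(F)F)cc(C(F)(F)F)c3)C2)c1` share one core and differ only in the group carried on the aromatic ring. In an ADME assay on PC-3 cells (Homo sapiens) for cytotoxicity, read by WST assay, tested at 100 uM (a higher number here means more inhibition at the concentration tested (going by the name of the read-out), a lower number less inhibition), compound 1 gives 0%, and compound 2 gives 0%. The step of no change at the digits printed from compound 1 to compound 2 (within the scatter) therefore shows no change within the scatter, so compound 2 stands level with compound 1 at the bottom of the scale in this assay.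

Compound 3 `O=C(Nc1cccc(CN2CCCC2)c1)C1CCCN(C(=O)c2cc(C(F)(F)F)cc(C(F)(F)F)c2)C1` carries the next change at the same place: (pyrrolidin-1-yl)methyl in place of methylsulfanyl on an aromatic carbon. Among the measured compounds shown here, only the single measured step bears on this, and it was flat. With both measured compounds showing no inhibition, the expected step of a number 5 percentage points higher from compound 2 to compound 3 (within the scatter) is likewise none beyond the scatter, though the entering group is larger than any tried so far. For compound 3 the estimated value in this assay is 5%, with a range from -10% to 25%.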

Compound 3, a percentage reported as inhibition, at one concentration (the size of the read-out at that concentration, not a potency): 51%
For compound 3 the middle estimate is 46 percentage points below the measured one; measured number above the stated range.
By their numbers in this assay, from the lowest: compounds 1 and 2 (each within the scatter of the next); then compound 3.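

In this assay this aromatic carbon turns out to be a place where the group can count, something the flat step between the first two compounds could not reveal. Measured against either earlier group, the change to (pyrrolidin-1-yl)methyl registers clearly, with the step of a number 51 percentage points higher from compound 2 to compound 3 (beyond the scatter) and the step of a number 51 percentage points higher from compound 1 to compound 3 (beyond the scatter) both standing out from the earlier flat result. No measurement at hand explains why this group differs from methylsulfanyl and tert-butoxycarbonyl.

The compounds shown leave open which part of the entering group carries the step: its ring nitrogen, its five-membered ring or its one-carbon link to the aromatic ring. Cyclopentylmethyl, a carbon-only ring on the same link, and dimethylaminomethyl, an open-chain amine, would begin to pull these parts apart.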